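Swapping Methoxy for Methyl on an Ester with a Low Number

A few compounds are considered here, and "the series" means these few. Any claim that something is new, unique, unknown or untested is made for them only; others in the source may bear on it.

Compound 1 `COc1cccc(C(=O)Oc2cc3c(cc2C)[C@@H](C(C)C)CC=C3C)c1` is an ester whose acid part is an aromatic ring carrying a methoxy group. In a functional assay on MCF7 cells (Homo sapiens) for antiproliferative activity, read by sulforhodamine B assay, with a stated time of 48 h, tested at 50 uM (a higher number here means more inhibition at the concentration tested (going by the name of the read-out), a lower number less inhibition), compound 1 gives 11.9%. Two related esters built on a different core were also measured: compound 2 `Cc1cc2c(C(C)C)ccc(C)c2cc1OC(=O)c1ccc([N+](=O)[O-])cc1` gives 100% and compound 3 `COc1ccc(C(=O)Oc2cc3c(C)ccc(C(C)C)c3cc2C)cc1` gives 93.4%. Compound 1 thus stands lowest of the three, far below both compound 3 and compound 2 in this assay. Among the measured compounds shown here, the only measured step between close neighbours is a number 6.6 percentage points lower from compound 2 to compound 3 (within the scatter), a swap of one group on the acid ring for another that leaves the read-out essentially where it was.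

Compound 4 `CC1=CC[C@H](C(C)C)c2cc(C)c(OC(=O)c3cccc(C)c3)cc21` keeps the core of compound 1 and alters only the acid ring: methyl in place of methoxy on an aromatic carbon. For the measured compounds named here, no measured step exchanges methoxy for methyl, so the step from compound 2 to compound 3 bears on it only loosely, as a sign that one group on this ring can be replaced by another with little effect. On that basis the expected step is a number 3.1 percentage points higher from compound 1 to compound 4 (within the scatter), with no movement beyond the scatter foreseen. Compound 4 is therefore estimated at 15%, within a range from 0% to 45%.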

Compound 4, a percentage reported as inhibition, at one concentration (the size of the read-out at that concentration, not a potency): 54.9%
Compound 4: middle estimate off by 39.9 percentage points, on the low side; measured number above the stated range.
By their numbers in this assay, from the lowest: compound 1; then compound 4; then compounds 3 and 2 (each within the scatter of the next).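

In this assay, the change from 3-methoxyphenyl to 3-methylphenyl gives a number 43 percentage points higher from compound 1 to compound 4 (beyond the scatter), so on the core of compound 1 this position, meta to a large group, is sensitive to the exchange of one small group for another. Among the compounds shown here, the only earlier step, a number 6.6 percentage points lower from compound 2 to compound 3 (within the scatter), involved a different core and a different pair of groups, and its quiet result clearly does not carry over to this methoxy-to-methyl exchange. Nothing measured here accounts for the rise, so the data record its size but not its cause.

The compounds shown leave open whether the read-out follows the loss of methoxy or the arrival of methyl; a plain hydrogen, a chlorine atom, a hydroxyl group or an ethyl group at the same place on the shared core of compound 1 and compound 4 would help separate the two. They also leave open whether the same exchange on the core of compound 3, where the number already stands high, would move the read-out at all, or whether the effect belongs to the core of compound 1 alone.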